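A few compounds are considered here, and "the series" means these few. Any claim that something is new, unique, unknown or untested is made for them only; others in the source may bear on it.

Compound 3 `O=C(O)c1ccccc1-c1ccc(CCc2ncc(CC3CCCCCC3)[nH]2)cc1` gives the lowest number of the three measured in an in vitro functional assay on cells for agonist activity at Bombesin receptor subtype-3 (Mus musculus), read by luminescence and calcium flux (a lower number here means that less compound is needed, a higher number that more compound is needed for the effect), at 5.7 nM. Compound 1 `O=C(O)c1ccccc1-c1ccc(CCc2ncc(Cc3ccccc3F)[nH]2)cc1` gives 9.5 nM, and a 1.7-fold lower number from compound 1 to compound 3 (0.22 log units; within the scatter), within the scatter. Compound 2 `CCCCc1cnc(C(CC)Cc2ccc(-c3ccccc3C(=O)O)cc2)[nH]1` gives 340 nM, a higher number than either. Compound 4 `CCCCc1cnc(CCc2ccc(-c3ccccc3C(=O)O)cc2)[nH]1` differs from compound 3 by propyl in place of cycloheptyl on a saturated chain carbon bound to an aromatic carbon. For the measured compounds named here, only the step from compound 1 to compound 3 bears on this place, and it shows that two ring groups there give numbers within the scatter of each other; no measured step shows what a short chain does there. Compound 2, which also holds a butyl, gives 340 nM. Compound 4 is therefore expected to give 60 nM, with a range from 15 nM to 300 nM. The estimated step of an 11-fold higher number from compound 3 to compound 4 (1.02 log units; beyond the scatter) is expected to be a higher number, beyond the scatter.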

Compound 4, half-maximal effective concentration: 93 nM
Compound 4: the middle estimate sits 1.6-fold (0.19 log units) below what was measured, within the range that was stated.
By their numbers in this assay, from the lowest: compounds 3 and 1 (each within the scatter of the next); then compound 4; then compound 2.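

In this assay, propyl at this place on a saturated chain carbon bound to an aromatic carbon separates from both ring groups, which the earlier step between those two ring groups could not show. Propyl in place of cycloheptyl gives a 16-fold higher number from compound 3 to compound 4 (1.21 log units; beyond the scatter) and propyl in place of 2-fluorophenyl gives a 9.8-fold higher number from compound 1 to compound 4 (0.99 log units; beyond the scatter) in the same assay. Hydrogen in place of ethyl, a change at another place, gives a 3.7-fold lower number from compound 2 to compound 4 (0.56 log units; beyond the scatter) as a smaller step. Still open, as far as these compounds go, is where a longer chain or an amine would fall at this place, and whether ethyl would cost as much alongside cycloheptyl. Nothing available gives a reason for these steps.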